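Working notes: from compound 3 to compound 4

A few compounds are considered here, and "the series" means these few. Any claim that something is new, unique, unknown or untested is made for them only; others in the source may bear on it.

In a functional assay on BT-20 cells (Homo sapiens) for cytotoxicity, read by MTT assay, with a stated time of 68 h (a higher number here means a weaker inhibitor, a lower number a stronger inhibitor), compound 3 (`O=C(/C=C/c1cccc(OCc2ccccc2)c1)c1ccc(Cl)cc1`) gives 63200 nM. Compound 1 (`O=C(/C=C/c1cccc(OCc2ccccc2)c1)c1ccc([N+](=O)[O-])cc1`) gives 80900 nM, and the comparison, a 1.3-fold lower number from compound 1 to compound 3 (0.11 log units; within the scatter), leaves these two level. Compound 2 (`O=C(/C=C/c1cccc(OCc2ccccc2)c1)c1ccc(Cl)cc1Cl`) gives 19200 nM. The remaining comparison is a 3.3-fold higher number from compound 2 to compound 3 (0.52 log units; beyond the scatter), so compound 3 stands well apart from this member of the series.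

The next member is compound 4 (`O=C(/C=C/c1cccc(OCc2ccccc2)c1)c1ccccc1Br`), with 2-bromophenyl in place of 4-chlorophenyl on a carbonyl carbon.

Two measured steps at this same place bear most directly on the change. The first is a 4.2-fold lower number from compound 1 to compound 2 (0.62 log units; beyond the scatter), and the second is the comparison already given for compound 3. Both are modest. Within the data shown here, no measured compound carries a 2-bromophenyl group, so the evidence is indirect. The closest match is the 2,4-dichlorophenyl group of compound 2, with its value of 19200 nM. That match points towards a lower number, but compound 4 lacks the second halogen, so only part of that modest step is expected, and the step may not clear the scatter.

The expected change is a 1.6-fold lower number from compound 3 to compound 4 (0.20 log units; within the scatter). Compound 4 is expected at 40000 nM, with an estimated range of 16000 nM to 90000 nM.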

Compound 4, half-maximal inhibitory concentration: 1800 nM
For compound 4 the middle estimate is 22-fold (1.35 log units) above the measured one, and the stated range ends above it.
By their numbers in this assay, from the lowest: compound 4; then compound 2; then compounds 3 and 1 (each within the scatter of the next).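

Working from this assay, the replacement of 4-chlorophenyl by 2-bromophenyl on the carbonyl carbon gives a 35-fold lower number from compound 3 to compound 4 (1.55 log units; beyond the scatter), a far larger step than any among the earlier compounds, which had suggested only modest movement at this place. The same holds against the other two members, with an 11-fold lower number from compound 2 to compound 4 (1.03 log units; beyond the scatter) and a 45-fold lower number from compound 1 to compound 4 (1.65 log units; beyond the scatter), so compound 4 has the lowest number of the four and the second chlorine of the 2,4-dichlorophenyl group in compound 2 does not reach it. No supporting measurement is available to account for this gap.

The change alters both the halogen and its place on the aromatic ring, and the compounds shown cannot separate these two contributions. A 2-chlorophenyl group and a 4-bromophenyl group on the same core would address that question, while an unsubstituted phenyl group would show how much of the low number of compound 4 depends on having any halogen at all.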